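Thiophene for Naphthalene in a Coumarin-Linked Chalcone Series

A few compounds are considered here, and "the series" means these few. Any claim that something is new, unique, unknown or untested is made for them only; others in the source may bear on it.

Measured compounds:
Compound 1 `COc1cc(/C=C/C(=O)/C=C/c2cccc3ccccc23)ccc1OCc1cn(CCCOc2cc(=O)oc3ccccc23)nn1` — 8%
Compound 2 `COc1cc(/C=C/C(=O)/C=C/c2ccco2)ccc1OCc1cn(CCCCCOc2cc(=O)oc3ccccc23)nn1` — "not active" (no number reported)
Compound 3 `COc1cc(/C=C/C(=O)/C=C/c2cccs2)ccc1OCc1cn(CCCCCOc2cc(=O)oc3ccccc23)nn1` — "not active" (no number reported)

In a functional assay on PC-3 cells (Homo sapiens) for inhibition, read by sulforhodamine B assay, with a stated time of 48 h, tested at 50 uM (on this read-out lower numbers stand for less inhibition of growth and higher numbers for more inhibition of growth at the one concentration tested), compound 1 gives 8%, the only numerical result among the three measured compounds; compound 2 and compound 3 are each reported without a number. Compound 4 `COc1cc(/C=C/C(=O)/C=C/c2cccs2)ccc1OCc1cn(CCCOc2cc(=O)oc3ccccc23)nn1` is still to be measured. It differs from compound 1 by thiophen-2-yl in place of naphthalen-1-yl on a double-bonded chain carbon bound to a double-bonded chain carbon. Among the compounds with values here, no step between two measured compounds is available, so the expectation rests on compound 1 alone. Given that compound 1 gives 8%, the step of a number 3 percentage points lower from compound 1 to compound 4 (within the scatter) is expected to be small and within the scatter, with a slight downward lean. Compound 4 is therefore estimated at 5%, in the range 0% to 15%.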

Compound 4, percent growth inhibition at one concentration: "not active" (no number reported)
The entry for compound 4 holds no number, so the estimate cannot be set against anything.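

Within the data shown here, compound 4 is reported in this assay without a number, so no step from compound 1 can be read. Nothing shown here accounts for this result. As far as these compounds go, whether thiophen-2-yl in place of naphthalen-1-yl alters growth inhibition remains open.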